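The source may report more compounds than this note shows. Statements on the series, on what has been measured and on what is new or still open speak of the compounds shown alone.

For the measured compounds named here, in an ADME assay on microsomes from liver (Rattus norvegicus) for metabolic stability, read by LC-MS, tested at 1 uM (a lower number here means that the compound disappears faster, a higher number that the compound lasts longer), compound 1 `Nc1ncnc2c1c(Oc1cccc(Cl)c1)nn2CC1CCOCC1` gives 0.233 h, the higher of the two numbers measured so far. Compound 3 `Cc1cccc(Oc2nn(C(C)(C)C)c3ncnc(N)c23)c1` gives 0.07 h, and the gap between these two lies beyond the usual scatter of this kind of measurement. Compound 2 `Nc1ncnc2c1c(Cc1cc(F)cc(F)c1)nn2CC1CCNCC1` gives > 1 h, which is a limit of the assay rather than a number (the limit of > 1 h in this assay, at which 1 of the 3 values shown sits). Going by the values given here, none of these three compounds differs from another in only one place, so no single structural step has yet been measured.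

Compound 4 `Nc1ncnc2c1c(Oc1cccc(Cl)c1)nn2CC1(C(F)(F)F)CC1` has not been tested. It differs from compound 1 in one place: 1-(trifluoromethyl)cyclopropyl in place of oxan-4-yl on a saturated chain carbon bound to an aromatic nitrogen. Among the compounds with values here, none of the measured compounds shows how this particular change affects the half-life, so the expectation rests on compound 1 alone. The change is expected to give a 1.5-fold higher number from compound 1 to compound 4 (0.18 log units; within the scatter), a step within or only slightly beyond the usual scatter, with either direction possible. Compound 4 is therefore estimated at 0.35 h, with a range from 0.15 h to 0.9 h.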

Compound 4, half-life: 0.183 h
Compound 4: the middle estimate sits 1.9-fold (0.28 log units) above what was measured; the measured number falls inside the stated range.
By their numbers in this assay, from the lowest: compound 3; then compounds 4 and 1 (each within the scatter of the next). At a limit, above all of these: compound 2.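

For the compounds shown here, the swap at this position gives the first single change that can be read in this assay: 1-(trifluoromethyl)cyclopropyl in place of oxan-4-yl on a saturated chain carbon bound to an aromatic nitrogen gives a 1.3-fold lower number from compound 1 to compound 4 (0.10 log units; within the scatter). With the rest of the structure held fixed, the half-life therefore cannot be told apart for these two groups, even though one ring holds an oxygen and the other is carbon only and carries three fluorines. Nothing measured here gives a reason for this result.

On these data alone, whether another group at this place, such as a carboxylic acid or a longer chain of plain carbons, would shift the half-life beyond the scatter stays open. Going by these compounds alone, compound 2 and compound 3 each differ from compound 1 and compound 4 in more than one place, so no steps to them can be read.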